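The source may report more compounds than this note shows. Statements on the series, on what has been measured and on what is new or still open speak of the compounds shown alone.

Compound 1 `CNc1nc(N)nc2c1ncn2/C=C1/CC1(CO)CO` is tested in an ADME assay on Akata cells (Homo sapiens) for cytotoxicity, with a stated time of 7 days; on this read-out lower numbers stand for higher toxicity in this test and higher numbers for lower toxicity in this test. In this assay compound 1 reaches only a limit, reported as > 24000 nM. Compound 2 `CC(C)CSc1nc(N)nc2c1ncn2/C=C1/CC1(CO)CO` likewise stops at a limit, given as > 20000 nM. Compound 3 `CCOc1nc(N)nc2c1ncn2/C=C1/CC1(CO)CO` also stops at a limit, recorded as > 20000 nM. Two of the three measured compounds sit at the limit of > 20000 nM in this assay, at which 2 of the 3 values shown sit, and the third at the limit of > 24000 nM in this assay, at which 1 of the 3 values shown sits. Consequently the step that the two limits leave unreadable from compound 1 to compound 2, the step that the two limits leave unreadable from compound 1 to compound 3 and the step that the two limits leave unreadable from compound 2 to compound 3 cannot be sized. Compound 4 `Nc1nc(NCc2ccccc2)c2ncn(/C=C3/CC3(CO)CO)c2n1` differs from compound 1 by phenyl in place of hydrogen on a saturated chain carbon bound to a nitrogen on an aromatic ring. Going by the values given here, no measured step bears on this change, so no shift beyond the scatter is expected, and the step of a number no higher from compound 1 to compound 4 (the limit leaves the size open) is an estimate only. Compound 4 is expected at 24000 nM, within 10000 nM to 60000 nM, most likely again a limit.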

Compound 4, half-maximal cytotoxic concentration: > 24000 nM
Compound 4: a limit, no number (the forecaster's own chance of this, stated with the estimate: 75%); the middle value sits exactly at the limit.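

In this assay compound 4 stops at a limit, as compounds 1, 2 and 3 do, so no step among these four can be read: the limit of > 24000 nM in this assay, at which 2 of the 4 values shown sit. The compounds shown leave open at what concentration any of them becomes toxic to these cells.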